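Working notes: compound 4 from compound 3, lipophilicity

This account rests on a few compounds, and the source may have more. Where it says the series, first, only, none or still open, it means among the compounds named here.

Measured compounds:
- compound 1, `CC(=O)N[C@@H]1CCC[C@H](C(=O)Nc2cc(-c3cnn4c3CCCC4)c(F)cn2)C1`: in a physicochemical assay for lipophilicity, using the shake flask method, measured as octanol-water partition, at pH 7.4 (on this read-out higher numbers stand for higher lipophilicity and lower numbers for lower lipophilicity), compound 1 gives 2.9
- compound 2, `CC(=O)N[C@@H]1CCC[C@H](C(=O)Nc2cc(-c3nnn4ccccc34)c(Cl)cn2)C1`: in this assay compound 2 gives 2
- compound 3, `CC(=O)N[C@@H]1CCC[C@H](C(=O)Nc2cc(-c3cnn4c3CC(C)(C)C4)c(F)cn2)C1`: in this assay compound 3 gives 3.3

Compound 3 stands highest of the three numbers. Among the measured compounds shown here, its nearest neighbour is compound 1, and the one measured step that links them, a number 0.40 log units higher from compound 1 to compound 3 (beyond the scatter), lies beyond the scatter. For the measured compounds named here, compound 2 is the furthest away; its value in this assay sits well below that of compound 3, though no single-point step connects the two.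

Compound 4, `CC(=O)N[C@@H]1CCC[C@H](C(=O)Nc2cc(-c3cnn4c3CC(C)(C)C4)c(C)cn2)C1`, is not yet measured. It differs from compound 3 by methyl in place of fluoro on an aromatic carbon.

Going by the values given here, no measured step bears directly on this change: the only step in hand, a number 0.40 log units higher from compound 1 to compound 3 (beyond the scatter), concerns a different place and a different kind of group, and no measured pair exchanges fluoro for methyl. The expectation therefore rests on the change alone and is held loosely. A small rise in this assay is expected, of about a number 0.30 log units higher from compound 3 to compound 4 (within the scatter), plausibly just beyond the scatter but not by much.

For compound 4 the estimate in this assay is 3.6, with a range from 3.2 to 4.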

Compound 4, distribution coefficient: 3.1
The estimate for compound 4 lay 0.50 log units above the measured number, outside the stated range (below it).
By their numbers in this assay, from the lowest: compound 2; then compounds 1, 4 and 3 (each within the scatter of the next, the first and the last beyond it).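

The exchange of fluoro for methyl on an aromatic carbon, ortho to a large group and para to a large group, gives a number 0.20 log units lower from compound 3 to compound 4 (within the scatter) in this assay and so does not separate the two groups on this read-out. Among the compounds shown here, this is the first measured pair at this position; the earlier step, a number 0.40 log units higher from compound 1 to compound 3 (beyond the scatter) at a different place, is the only one of the two that lies beyond the scatter, which on these few compounds puts the larger measured difference at that other place and not at this one. Nothing in hand offers an explanation for fluoro and methyl reading alike here.

As far as these compounds go, only the background of compound 3 carries this exchange, so whether fluoro and methyl also read alike on the core of compound 1 remains open. Also open, from the compounds shown here alone, is how this assay would respond at this position to a group of a different kind, such as an amine, a carboxylic acid or a longer chain.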